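Acyl chain variation on the shared core: cytotoxicity notes

The source may report more compounds than this note shows. Statements on the series, on what has been measured and on what is new or still open speak of the compounds shown alone.

Measured so far:
- compound 1, `CCC(=O)c1ccc2c(c1O)[C@@H]1c3c(ccc4c(=O)c(C)c(C)oc34)OC[C@@H]1C(C)(C)O2`: in a functional assay on MCF7 cells (Homo sapiens) for cytotoxicity, read by MTT assay (a higher number here means a weaker inhibitor, a lower number a stronger inhibitor), compound 1 gives > 100000 nM, a limit of the assay.
- compound 2, `CC(=O)c1ccc2c(c1O)[C@@H]1c3c(ccc4c(=O)c(C)c(C)oc34)OC[C@@H]1C(C)(C)O2`: in this assay compound 2 gives > 100000 nM, a limit of the assay.
- compound 3, `Cc1oc2c3c(ccc2c(=O)c1C)OC[C@H]1[C@@H]3c2c(ccc(C(=O)Cc3ccccc3)c2O)OC1(C)C`: in this assay compound 3 gives > 100000 nM, a limit of the assay.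

Compound 3 therefore has no number in this assay, only a limit, and the two other values shown are limits as well; all three sit at the same limit (the limit of > 100000 nM in this assay, at which 3 of the 3 values shown sit). The three steps among them, a step that the two limits leave unreadable from compound 1 to compound 2, a step that the two limits leave unreadable from compound 1 to compound 3 and a step that the two limits leave unreadable from compound 2 to compound 3, are each unreadable, since both ends rest on a limit. None of them gives a size that could be carried forward.

Compound 4, `Cc1oc2c3c(ccc2c(=O)c1C)OC[C@H]1[C@@H]3c2c(ccc(C(=O)c3ccccc3)c2O)OC1(C)C`, differs from compound 3 by phenyl in place of benzyl on a carbonyl carbon. Within the data shown here, no measured step bears on this change with a readable size. Among the measured compounds shown here, what the series shows is only that changes on the saturated chain carbon bound to the carbonyl carbon, from hydrogen through methyl to phenyl, have not brought any compound below the limit. On that basis compound 4 is expected to stay at or near the limit too, with the step that the limit leaves unreadable from compound 3 to compound 4 expected to be none beyond the scatter. The estimate for compound 4 in this assay is 150000 nM, with a range from 40000 nM to 500000 nM.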

Compound 4, half-maximal inhibitory concentration: > 100000 nM
Compound 4 gave a limit, no number (the forecaster's own chance of this, stated with the estimate: 75%); the middle value is on the limit's open side.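

No new step can be read: the steps joining compound 4 to compound 1, compound 2 and compound 3 all rest on limits at both ends, and the four compounds share one limit: the limit of > 100000 nM in this assay, at which 4 of the 4 values shown sit.

The compounds shown leave open whether any acyl group on the shared core gives a number in this assay, and so which change, if any, matters.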